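Replacing Fluoro with an Aminoethylamino Group

This account rests on a few compounds, and the source may have more. Where it says the series, first, only, none or still open, it means among the compounds named here.

Compound 1 `COc1c(F)c(F)cc2c(=O)c(C(=O)O)cn(Cc3ccc(-c4ccccc4)cc3)c12` is the starting point. In an assay on isolated protein for inhibition of DNA topoisomerase 1 (Homo sapiens), with a stated time of 15 min, tested at 200 uM (on this read-out lower numbers stand for less inhibition and higher numbers for more inhibition at the one concentration tested (going by the name of the read-out)), compound 1 gives "not active" (no number reported), so no single number places it. Two related compounds carry basic side chains: in this assay compound 2 `CNC[C@@H]1CCN(c2cc3c(cc2F)c(=O)c(C(=O)O)cn3Cc2ccc(-n3cccn3)cc2)C1` gives 10%, and compound 3 `O=C(O)c1cn(Cc2ccc(-n3cccn3)cc2)c2cc(NC[C@@H]3CCNC3)c(F)cc2c1=O` gives 10%. The step of no change at the digits printed from compound 2 to compound 3 (within the scatter) shows the read-out unchanged. Compound 4 `COc1c(NCCN)c(F)cc2c(=O)c(C(=O)O)cn(Cc3ccc(-c4ccccc4)cc3)c12` differs from compound 1 by (2-aminoethyl)amino in place of fluoro on an aromatic carbon. Among the measured compounds shown here, no measured step matches this change, and compound 1 offers no number to step from, so the expectation rests on the amine-bearing compounds. Since compound 2 gives 10% and compound 3 gives 10%, compound 4 is expected to give 10%, ranging from 0% to 30%.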

Compound 4, a percentage reported as inhibition, at one concentration (the size of the read-out at that concentration, not a potency): 10%
Estimate against measurement, compound 4: no gap at the digits printed; low and high end bracket the measured number.
By their numbers in this assay, from the lowest: compounds 2, 3 and 4 (each within the scatter of the next).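

In this assay, among the compounds shown here, compound 1 gives "not active" (no number reported) and so offers no number to step from, leaving no new step to compound 4 that can be read. The compounds shown leave open what (2-aminoethyl)amino in place of fluoro does to this read-out, and no measured evidence bears on the result.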